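The source may report more compounds than this note shows. Statements on the series, on what has been measured and on what is new or still open speak of the compounds shown alone.

Measured so far in a functional assay on HCC827 cells (Homo sapiens) for inhibition, read by fluorescence, with a stated time of 72 h (a higher number here means a weaker inhibitor of growth, a lower number a stronger inhibitor of growth), are two compounds:
- compound 1 `COc1ccc(Nc2nc(N[C@H]3CC[C@H](N)CC3)nc3c2ncn3CCC(C)C)c(OC)c1` gives 32900 nM
- compound 2 `CC(C)CCn1cnc2c(Nc3ccc(Cl)cc3)nc(N[C@H]3CC[C@H](N)CC3)nc21` gives 10200 nM

Of the two, compound 2 has the lower number and is therefore the stronger inhibitor of growth. Compound 3 `CCCCCCn1cnc2c(Nc3ccc(Cl)cc3)nc(N[C@H]3CC[C@H](N)CC3)nc21` is compound 2 with one change, an isopentyl chain lengthened and straightened to hexyl. The difference is butyl in place of isopropyl on a saturated chain carbon, two bonds along the chain from an aromatic nitrogen and it lies on a saturated chain carbon, two bonds along the chain from an aromatic nitrogen.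

Among the compounds with values here, only one measured step is available, and it bears on this change only indirectly. That step, a 3.2-fold lower number from compound 1 to compound 2 (0.51 log units; beyond the scatter) and it came from placing 4-chlorophenyl in place of 2,4-dimethoxyphenyl on a nitrogen on an aromatic ring. It therefore says nothing direct about the chain, and no chain change has yet been measured. In this assay a small change is expected, most likely none beyond the scatter, with no firm direction. The expected result is a 1.3-fold lower number from compound 2 to compound 3 (0.11 log units; within the scatter) and this remains a cautious guess. The estimate for compound 3 is 8000 nM with an expected range from 3000 nM to 20000 nM in this measurement.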

Compound 3, concentration for 50% growth inhibition: 11700 nM
The estimate for compound 3 lay 1.5-fold (0.17 log units) below the measured number; the range from low to high includes it.
By their numbers in this assay, from the lowest: compounds 2 and 3 (each within the scatter of the next); then compound 1.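

Within the data shown here, exchanging isopentyl for hexyl, which is butyl in place of isopropyl on a saturated chain carbon, two bonds along the chain from an aromatic nitrogen, gives a 1.1-fold higher number from compound 2 to compound 3 (0.06 log units; within the scatter) in this assay and is the first measured change at this position. Within this pair, the branched and the straight chain therefore cannot be told apart in this assay, whereas the earlier change on the other side of the molecule, a 3.2-fold lower number from compound 1 to compound 2 (0.51 log units; beyond the scatter), lay beyond the scatter. Nothing measured here explains why compound 2 and compound 3 read alike.

This single pair cannot show whether other groups at this position would also leave the number within the scatter, such as a chain ending in an amine or a carboxylic acid, a longer chain such as decyl, or a shorter one such as ethyl. It also leaves open whether the exchange of isopentyl for hexyl would read the same with the 2,4-dimethoxyphenyl group of compound 1 in place of 4-chlorophenyl.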